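A New Ring at the End of the Side Chain

The source may hold more compounds than are shown below. What is called first, only, known or untested is meant among the compounds shown, and "the series" means these compounds.

Two compounds share a core and differ only at one ring. Compound 1 `COc1cc2c(Oc3ccc(NC(=O)c4nn(-c5ccc(Br)cc5)c(=O)c5ccccc45)cc3F)ccnc2cc1OCCCN1CCCC1` carries a 4-bromophenyl on an aromatic nitrogen, and in a functional assay on MKN-45 cells (Homo sapiens) for cytotoxicity, read by MTT assay, with a stated time of 72 h (on this read-out lower numbers stand for stronger inhibition and higher numbers for weaker inhibition), compound 1 gives 230 nM. Compound 2 `COc1cc2c(Oc3ccc(NC(=O)c4nn(-c5ccccc5Br)c(=O)c5ccccc45)cc3F)ccnc2cc1OCCCN1CCCC1` carries a 2-bromophenyl there instead, and in this assay compound 2 gives 410 nM. The step of a 1.8-fold higher number from compound 1 to compound 2 (0.25 log units; within the scatter) lies within the scatter, so the two numbers cannot be told apart; on the numbers shown, compound 2 sits at the top of the two, with compound 1 its nearest neighbour. Compound 3 `COc1cc2c(Oc3ccc(NC(=O)c4nn(-c5ccccc5Br)c(=O)c5ccccc45)cc3F)ccnc2cc1OCCCN1CCN(C)CC1` keeps the 2-bromophenyl of compound 2 and changes the far end of the chain: 4-methylpiperazin-1-yl in place of pyrrolidin-1-yl on a saturated chain carbon, three bonds along the chain from an oxygen on an aromatic ring. No measured step touches this part of the molecule; the only step shown concerns the bromophenyl ring. With no comparable change to lean on, the expectation for compound 3 is a step of a 1.0-fold lower number from compound 2 to compound 3 (0.01 log units; within the scatter) that does not reach beyond the scatter in this assay. Compound 3 is therefore estimated at 400 nM, within a range from 150 nM to 1100 nM.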

Compound 3, half-maximal inhibitory concentration: 400 nM
For compound 3 middle estimate and measured number coincide at the digits printed; measured number inside the range.
By their numbers in this assay, from the lowest: compounds 1, 3 and 2 (each within the scatter of the next).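

Within the data shown here, with the 2-bromophenyl held fixed, the step of a 1.0-fold lower number from compound 2 to compound 3 (0.01 log units; within the scatter) gives a first reading at the far end of the chain. In this assay a five-membered ring with 1 hetero atom and a six-membered ring with 2 hetero atoms, the larger one carrying a methyl group, cannot be told apart at this place, so this particular change leaves the cell read-out unresolved from that of compound 2. Nothing available offers a reason for this match.

From the compounds shown here alone, whether 4-methylpiperazin-1-yl would read the same alongside the 4-bromophenyl of compound 1 remains open. Also open, going by these compounds, is what a morpholine ring, an open-chain dimethylamino group or a longer chain to the same amine would do here, since two ring amines at a single chain length give only a narrow view of this position.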